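Trimming a Methoxy Group on a Weakly Active Triazole

This account rests on a few compounds, and the source may have more. Where it says the series, first, only, none or still open, it means among the compounds named here.

Measured so far:
compound 1, `COc1cc(-n2cc(-c3ccc(N)cc3)nn2)cc(OC)c1OC`: > 10000 nM
compound 2, `COc1ccc(-c2cn(-c3ccc(OC)cc3)nn2)cc1`: > 100 nM
compound 3, `COc1ccc(-c2cn(-c3ccc(OC)c(OC)c3)nn2)cc1`: > 10000 nM

Of the compounds shown here, three have been tested in a functional assay on MDA-MB-231 cells (Homo sapiens) for cytotoxicity, read by MTT assay; on this read-out higher numbers stand for weaker inhibition and lower numbers for stronger inhibition. The value for compound 1 is a limit of the assay, > 10000 nM. The value for compound 2 is also a limit, > 100 nM, as is that for compound 3, > 10000 nM. Because the limit of > 10000 nM in this assay, at which 2 of the 3 values shown sit, and (the limit of > 100 nM in this assay, at which 1 of the 3 values shown sits), no number for any of the three is actually known, and the difference between the core of compound 1 and the core of compound 3 is not broken down here.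

Compound 3 and compound 2 differ in one place, (hydrogen in place of methoxy on an aromatic carbon), and the size of that step, a step that the two limits leave unreadable from compound 3 to compound 2, cannot be read from two limits.

The compound still to be measured is compound 4, `COc1cc(OC)cc(-n2cc(-c3ccc(N)cc3)nn2)c1`. It differs from compound 1 by hydrogen in place of methoxy on an aromatic carbon, the same kind of change as from compound 3 to compound 2, though the surroundings differ: here the carbon is ortho to two methoxy groups and para to a large group, there it was ortho to a methoxy group and meta to a large group.

Since compound 1 gave only > 10000 nM, the expected step that the limit leaves unreadable from compound 1 to compound 4 rests on no readable precedent. Compound 4 is expected to give about 20000 nM in this assay, with a range from 5000 nM to 80000 nM, and most likely only another limit.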

Compound 4, half-maximal inhibitory concentration: > 10000 nM
Compound 4: no number, only a limit; the forecaster's own chance of this, stated with the estimate: 80%; the middle value lies beyond the limit too.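

Compound 4 gives > 10000 nM in this assay, which is a limit and not a number. Compound 1 also sits at a limit, so no new step can be read between compound 1 and compound 4: the limit of > 10000 nM in this assay, at which 3 of the 4 values shown sit.

The compounds shown leave open what number any of the four would give, and whether hydrogen in place of methoxy on an aromatic carbon changes that number at all.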